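Swapping the alkyne tail of compound 3 for a hydroxyoxane

The source may report more compounds than this note shows. Statements on the series, on what has been measured and on what is new or still open speak of the compounds shown alone.

Compound 1 `COc1cc[nH]c1/C=C1\C(=O)Nc2ccc(F)c(I)c21`: in a functional assay on MDA-MB-435 cells (Homo sapiens) for inhibition (a higher number here means a weaker inhibitor, a lower number a stronger inhibitor), compound 1 gives > 30000 nM, which is a limit of the assay rather than a number.
Compound 2 `COc1cc[nH]c1/C=C1\C(=O)Nc2ccc(F)c(C#C[C@H](C)O)c21`: in this assay compound 2 gives 190 nM.
Compound 3 `CN[C@H](C#Cc1c(F)ccc2c1/C(=C/c1[nH]ccc1OC)C(=O)N2)CO`: in this assay compound 3 gives 349 nM.

Of the two numbers actually measured, compound 3 carries the higher one, but its gap to compound 2 is within the scatter: a 1.8-fold higher number from compound 2 to compound 3 (0.26 log units; within the scatter). Compound 4 `COc1cc[nH]c1/C=C1\C(=O)Nc2ccc(F)c(C#CC3(O)CCOCC3)c21` is not yet measured. It differs from compound 3 in one place: 4-hydroxyoxan-4-yl in place of 2-hydroxy-1-(methylamino)ethyl on a triple-bonded carbon. Two kinds of measured step bear on this. Putting 3-hydroxybut-1-yn-1-yl or 4-hydroxy-3-(methylamino)but-1-yn-1-yl in place of iodo on the shared core gave large drops: an at least 150-fold lower number from compound 1 to compound 2 (2.19 log units; beyond the scatter) and an at least 85-fold lower number from compound 1 to compound 3 (1.93 log units; beyond the scatter). Exchanging only the group on the triple-bonded carbon made little difference: a 1.8-fold higher number from compound 2 to compound 3 (0.26 log units; within the scatter). Compound 4 keeps the triple bond and changes only the group beyond it, so no step beyond the scatter is expected in this assay; the expected step is a 1.2-fold lower number from compound 3 to compound 4 (0.07 log units; within the scatter). The estimate for compound 4 is 300 nM, with a range from 90 nM to 1000 nM.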

Compound 4, half-maximal inhibitory concentration: 600 nM
Beside the measured number, compound 4's estimate is 2.0-fold (0.30 log units) below it, within the range that was stated.
By their numbers in this assay, from the lowest: compounds 2, 3 and 4 (each within the scatter of the next, the first and the last beyond it). At a limit, above all of these: compound 1.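

Putting 2-(4-hydroxyoxan-4-yl)ethynyl in place of iodo gives an at least 50-fold lower number from compound 1 to compound 4 (1.69 log units; beyond the scatter), so a tail carrying a six-membered ring and no nitrogen also works at this place on the shared core. Compound 1 stands at a limit of the assay, which makes that step a minimum only: the limit of > 30000 nM in this assay, at which 1 of the 4 values shown sits. The group on the triple-bonded carbon now shows its first effect beyond the scatter, with a 3.2-fold higher number from compound 2 to compound 4 (0.50 log units; beyond the scatter), while the exchange against the methylamino tail gives a 1.7-fold higher number from compound 3 to compound 4 (0.24 log units; within the scatter).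

Going by these compounds, it remains open how a carboxylic acid or a longer chain on the triple-bonded carbon would read in this assay. Every compound with a measured number here keeps the triple bond, so a saturated ethyl link in its place remains an open case.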